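The compounds below may be only part of what the source reports. "The series", "measured", "known", "first", "only" and "open" are said of these compounds alone.

Going by the values given here, compound 2 `CCCN(Cc1cccs1)C(=O)COc1ccc(C)cc1` gives 40 nM in an assay on HEK293 cells for agonist activity at transient receptor potential cation channel subfamily M member 8 (Homo sapiens), read by fluorescence and calcium flux, with a stated time of 15 min (a higher number here means that more compound is needed for the effect, a lower number that less compound is needed), and stands highest of the two numbers so far; its nearest neighbour is compound 1 `Cc1ccc(OCC(=O)N(Cc2cccs2)c2ncco2)cc1`, which in this assay gives 0.3 nM. Among the compounds with values here, the one measured step joining them, a 130-fold higher number from compound 1 to compound 2 (2.12 log units; beyond the scatter), concerns the group on the amide-type nitrogen, not the chain that is altered next. Compound 3 `Cc1ccc(OCC(=O)N(CCCO)Cc2cccs2)cc1` differs from compound 2 by hydroxy in place of hydrogen on a saturated chain carbon, three bonds along the chain from an amide-type nitrogen. Within the data shown here, no measured step bears on this change: the hydroxy enters on a saturated chain carbon, three bonds along the chain from an amide-type nitrogen, and no other compound in the set carries this group or any related one, so the size of such a step in this assay is open. Taking the value of compound 2 as the only anchor, the expected step is no change at the digits printed from compound 2 to compound 3 (within the scatter), with no move beyond the scatter assumed in either direction. Compound 3 is accordingly estimated at 40 nM in this assay, with a range from 10 nM to 160 nM to cover the uncertainty.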

Compound 3, half-maximal effective concentration: 3000 nM
The estimate for compound 3 lay 75-fold (1.88 log units) below the measured number; the measured number lies above the stated range.
By their numbers in this assay, from the lowest: compound 1; then compound 2; then compound 3.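

In this assay, the saturated chain on the amide-type nitrogen proves sensitive at its far end: hydroxy in place of hydrogen, three bonds along the chain from that nitrogen, gives a 75-fold higher number from compound 2 to compound 3 (1.88 log units; beyond the scatter), a large step and beyond the scatter. The earlier pair showed only that this nitrogen's substituent matters as a whole; this result shows that a single change within the propyl chain can also produce a large step, here of a size comparable to a 130-fold higher number from compound 1 to compound 2 (2.12 log units; beyond the scatter). Replacing 1,3-oxazol-2-yl with 3-hydroxypropyl gives a 10000-fold higher number from compound 1 to compound 3 (4.00 log units; beyond the scatter), which leaves compound 3 with the highest number of the three, and no available data account for the size of this step.

On these data alone, it remains open whether this step is specific to hydroxy or would also appear with a methoxy group, an amine or a carboxylic acid at the same chain end. Also unresolved is how it depends on chain length, for example with 2-hydroxyethyl or a longer hydroxyalkyl chain on the same nitrogen.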